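Swapping a Chlorophenyl Ester for a Methylstyryl Ester

The source may hold more compounds than are shown below. What is called first, only, known or untested is meant among the compounds shown, and "the series" means these compounds.

Compound 2 `COc1cc(C2Oc3cc([C@H]4Oc5cc(O)cc(O)c5C(=O)[C@@H]4O)ccc3OC2COC(=O)c2cccc(Cl)c2)ccc1O` gives 14200 nM in a functional assay on liver (Rattus norvegicus, strain Sprague-Dawley) for inhibition, with a stated time of 1 h; on this read-out higher numbers stand for weaker inhibition and lower numbers for stronger inhibition. Its only measured companion, compound 1 `COc1ccc(C(=O)OCC2Oc3ccc([C@H]4Oc5cc(O)cc(O)c5C(=O)[C@@H]4O)cc3OC2c2ccc(O)c(OC)c2)cc1`, gives 21000 nM in this assay, and the step of a 1.5-fold lower number from compound 1 to compound 2 (0.17 log units; within the scatter) lies within the scatter, so the two numbers cannot be told apart. Compound 3 `COc1cc(C2Oc3cc([C@H]4Oc5cc(O)cc(O)c5C(=O)[C@@H]4O)ccc3OC2COC(=O)/C=C/c2ccc(C)cc2)ccc1O` differs from compound 2 by 2-(4-methylphenyl)ethenyl in place of 3-chlorophenyl on a carbonyl carbon. Among the compounds with values here, the one measured step at this same carbonyl carbon, a 1.5-fold lower number from compound 1 to compound 2 (0.17 log units; within the scatter), stayed within the scatter, so for compound 3 a change of a 1.0-fold lower number from compound 2 to compound 3 (0.01 log units; within the scatter) is expected, nothing beyond the scatter. Compound 3 is therefore estimated at 14000 nM, between 6000 nM and 35000 nM.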

Compound 3, half-maximal inhibitory concentration: 14700 nM
The estimate for compound 3 lay 1.1-fold (0.02 log units) below the measured number; the range from low to high includes it.
By their numbers in this assay, from the lowest: compounds 2, 3 and 1 (each within the scatter of the next).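

In this assay, the carbonyl carbon now carries a third group, one with a double bond outside the aromatic ring, yet the result is a 1.0-fold higher number from compound 2 to compound 3 (0.02 log units; within the scatter) and a 1.4-fold lower number from compound 1 to compound 3 (0.15 log units; within the scatter) on this read-out. The 3-chlorophenyl, 4-methoxyphenyl and 2-(4-methylphenyl)ethenyl compounds therefore cannot be told apart here. Nothing available explains this outcome. Still open, from the compounds shown here alone, is whether a group without an aromatic ring, such as a plain alkyl chain, or one carrying an amine or a carboxylic acid, would move the number at this position.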